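The compounds below may be only part of what the source reports. "The series", "measured", "known", "first", "only" and "open" are said of these compounds alone.

Working notes on the series. Compound 2 `Cc1ccccc1Oc1ccc(N2CCC[C@H]2CC(=O)O)cc1` gives 74 nM in a functional assay on cells for agonist activity at Free fatty acid receptor 1 (Homo sapiens), read by FLIPR and calcium flux, with a stated time of 100 s (on this read-out higher numbers stand for an effect only at larger amounts of compound and lower numbers for an effect already at smaller amounts), and sits second highest of the three numbers there: compound 1 `Cc1ccccc1Oc1ccc(N2C[C@@H](C(F)(F)F)C[C@H]2CC(=O)O)cc1` gives 73 nM and compound 3 `CC(C)(C)c1ccccc1Oc1ccc(N2CCC[C@H]2CC(=O)O)cc1` gives 6500 nM. The step of a 1.0-fold higher number from compound 1 to compound 2 (0.01 log units; within the scatter) is within the scatter, whereas the step of an 88-fold higher number from compound 2 to compound 3 (1.94 log units; beyond the scatter) is large. Compound 4 `O=C(O)C[C@@H]1CCCN1c1ccc(Oc2cccc(Cl)c2)cc1` differs from compound 2 by 3-chlorophenyl in place of 2-methylphenyl on an oxygen on an aromatic ring. Going by the values given here, only the step from compound 2 to compound 3 touches the same phenyl ring, and it shows that a much bulkier group there costs a great deal; the entering 3-chlorophenyl is close in size to 2-methylphenyl, so no step beyond the scatter is expected, a 1.6-fold higher number from compound 2 to compound 4 (0.21 log units; within the scatter). For compound 4 the estimate in this assay is 120 nM, in the range 40 nM to 400 nM.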

Compound 4, half-maximal effective concentration: 680 nM
For compound 4 the middle estimate is 5.7-fold (0.75 log units) below the measured one, outside the stated range (above it).
By their numbers in this assay, from the lowest: compounds 1 and 2 (each within the scatter of the next); then compound 4; then compound 3.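

In this assay the exchange on this oxygen gives a step beyond the scatter (a 9.2-fold higher number from compound 2 to compound 4 (0.96 log units; beyond the scatter)), although 3-chlorophenyl and 2-methylphenyl have the same count of heavy atoms. This position therefore responds not only to the much larger tert-butyl (compound 3) but also to a change at equal heavy-atom count. No evidence at hand bears on the reason for this step. The step changes both the substituent and its place on the ring, so the compounds shown do not separate the two. 2-Chlorophenyl or 3-methylphenyl on the same oxygen would do so.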